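The compounds below may be only part of what the source reports. "The series", "measured", "known", "first", "only" and "open" are said of these compounds alone.

Notes on the series. Compound 1 `Fc1cccc(-c2nc(Nc3ccc(Cl)cc3)c3cc(F)ccc3n2)c1` carries a 4-chlorophenyl group on a nitrogen on an aromatic ring. In a functional assay on MCF7 cells (Homo sapiens) for cytotoxicity, read by MTT assay, with a stated time of 48 h (on this read-out higher numbers stand for weaker inhibition and lower numbers for stronger inhibition), compound 1 gives only a limit of the assay, > 50000 nM. Compound 2 `Fc1cccc(-c2nc(Nc3ccccc3Br)c3cc(F)ccc3n2)c1` carries 2-bromophenyl in place of 4-chlorophenyl on that nitrogen. In this assay compound 2 also returns a limit rather than a number, > 50000 nM. The step that the two limits leave unreadable from compound 1 to compound 2 cannot be sized, as both values sit at the limit of > 50000 nM in this assay, at which 2 of the 2 values shown sit. Compound 3 `Nc1ccc(Nc2nc(-c3cccc(F)c3)nc3ccc(F)cc23)cc1` is not yet measured; it differs from compound 2 by 4-aminophenyl in place of 2-bromophenyl on a nitrogen on an aromatic ring. Among the compounds with values here, the single measured step is unreadable, so no measured step gives a direction or size for this change; the two values shown say only that neither compound 1 nor compound 2 reached a number. The step that the limit leaves unreadable from compound 2 to compound 3 is expected to be small or not resolvable. Compound 3 is estimated at 60000 nM, within a range from 15000 nM to 200000 nM, most likely again reported as a limit.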

Compound 3, half-maximal inhibitory concentration: > 50000 nM
Compound 3: only a limit was reported; the forecaster's own chance of this, stated with the estimate: 75%; the middle value is on the limit's open side.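

In this assay compound 3 also gives only a limit, > 50000 nM. No step among compound 1, compound 2 and compound 3 can be read: the limit of > 50000 nM in this assay, at which 3 of the 3 values shown sit.

The compounds shown leave open whether any group on that nitrogen gives a numerical value in this assay.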